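From a chain to a ring at the assay limit

The source may hold more compounds than are shown below. What is called first, only, known or untested is meant among the compounds shown, and "the series" means these compounds.

In a functional assay on BaF3 cells (Mus musculus) for inhibition, read by CCK-8 assay, with a stated time of 72 h (on this read-out lower numbers stand for stronger inhibition of growth and higher numbers for weaker inhibition of growth), compound 1 (`COc1ccc(CNc2cc(Oc3ccc(NC(=O)Nc4ccc(C)c(C(F)(F)F)c4)cc3)ncn2)cc1`) gives 1000 nM as a measured number. Compound 2 (`Cc1ccc(NC(=O)Nc2ccc(Oc3cc(N)ncn3)cc2)cc1C(F)(F)F`) gives > 10000 nM as a limit of the assay, not a number. Compound 3 (`Cc1ccc(NC(=O)Nc2ccc(Oc3cc(NCCN)ncn3)cc2)cc1C(F)(F)F`) gives > 10000 nM as a limit too. Compound 3 therefore stands at the limit of > 10000 nM in this assay, at which 2 of the 3 values shown sit, with no number of its own.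

Compound 4 (`Cc1ccc(NC(=O)Nc2ccc(Oc3cc(N4CCN[C@H](C)C4)ncn3)cc2)cc1C(F)(F)F`) has not been measured yet. It puts 3-methylpiperazin-1-yl in place of (2-aminoethyl)amino on an aromatic carbon.

Going by the values given here, two measured steps bear on this place. The first is an at least 10-fold higher number from compound 1 to compound 2 (1.00 log units; beyond the scatter) and the second is an at least 10-fold higher number from compound 1 to compound 3 (1.00 log units; beyond the scatter) in the same direction. There is also a step that the two limits leave unreadable from compound 2 to compound 3 so that pair offers no size to carry over. Among the compounds with values here, the only number, from compound 1 at 1000 nM here, belongs to the one compound with a 4-methoxybenzyl group, which compound 4 lacks, so compound 4 is expected to stay weak. The expected step in this assay is an at least 1.6-fold lower number from compound 3 to compound 4 (0.22 log units; that floor lies within the scatter) and it should be small at best. For compound 4 the estimated value is 6000 nM with an estimated range from 1500 nM to 10000 nM as its ends.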

Compound 4, concentration for 50% growth inhibition: 8920 nM
Estimate against measurement, compound 4: 1.5-fold (0.17 log units) below; low and high end bracket the measured number.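

In this assay, compound 4 gives a number where compound 2 and compound 3 give only limits of the assay, which shows that a ring at this aromatic carbon can bring a readable value without the 4-methoxybenzyl group: the limit of > 10000 nM in this assay, at which 2 of the 4 values shown sit. That number does not amount to a demonstrated gain: the ring gives an at least 1.1-fold lower number from compound 3 to compound 4 (0.04 log units; that floor lies within the scatter) when it replaces the open chain, and an at least 1.1-fold lower number from compound 2 to compound 4 (0.04 log units; that floor lies within the scatter) when it replaces the plain amino group. The ring still falls short of the (4-methoxybenzyl)amino group, with an 8.9-fold higher number from compound 1 to compound 4 (0.95 log units; beyond the scatter), so compound 1 remains the strongest of the four, though only by a modest step from compound 4.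

The compounds shown do not tell whether the methyl group or the defined stereocentre of the 3-methylpiperazin-1-yl group contributes anything, which a plain piperazine ring or the opposite stereoisomer would address. They also leave open which part of the 4-methoxybenzyl group carries its advantage, a question that a plain benzylamino group, without the methoxy, could begin to answer.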